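Pyridin-2-yl for 4-(trifluoromethyl)phenyl: cytotoxicity working notes

A few compounds are considered here, and "the series" means these few. Any claim that something is new, unique, unknown or untested is made for them only; others in the source may bear on it.

Compound 1 `CC(=O)c1ccc2c(c1)nc(-c1ccccn1)n2C1CCCCC1`: > 100000 nM
Compound 2 `C/C(=N\NC(N)=O)c1ccc2c(c1)nc(-c1ccc(C(F)(F)F)cc1)n2C1CCCCC1`: > 100000 nM

Both entries come from an ADME assay on MDBK cells (Bos taurus) for cytotoxicity, read by MTT assay, with a stated time of 96 h; a lower number here means that less compound is tolerated, a higher number that more compound is tolerated. Compound 2 gives no number there, only the limit > 100000 nM. Among the compounds with values here, the measured series so far consists of the limit of > 100000 nM in this assay, at which 2 of the 2 values shown sit, so no measured step is available to size a change.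

The next compound, compound 3 `C/C(=N\NC(N)=O)c1ccc2c(c1)nc(-c1ccccn1)n2C1CCCCC1`, has pyridin-2-yl in place of 4-(trifluoromethyl)phenyl on an aromatic carbon. That carbon lies between two ring nitrogen atoms, next to the ring atom that bears a cyclohexyl group.

With compound 2 at the limit > 100000 nM, no step beyond the scatter is expected in this assay, in either direction. The expected change is a number no higher from compound 2 to compound 3 (the limit leaves the size open). Compound 3 is estimated at 100000 nM, with an expected range of 40000 nM to 200000 nM.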

Compound 3, half-maximal cytotoxic concentration: > 100000 nM
Compound 3: only a limit was reported (the forecaster's own chance of this, stated with the estimate: 75%); the middle value sits exactly at the limit.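

Compound 3, like compound 1 and compound 2, gives only a limit in this assay, so no step among these compounds can be read: the limit of > 100000 nM in this assay, at which 3 of the 3 values shown sit.

The compounds shown leave open where any of them stops being tolerated, and whether pyridin-2-yl in place of 4-(trifluoromethyl)phenyl changes that.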